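A few compounds are considered here, and "the series" means these few. Any claim that something is new, unique, unknown or untested is made for them only; others in the source may bear on it.

Compound 1 `CC(C)(C)c1cc(/C=C/C(=O)NCCC2CCN(Cc3ccccc3)CC2)cc(C(C)(C)C)c1O` is measured in a functional assay, read by spectrophotometry, with a stated time of 30 min (on this read-out higher numbers stand for weaker inhibition and lower numbers for stronger inhibition), and gives 81700 nM. Two close relatives carry fluorine on the benzyl ring: compound 2 `CC(C)(C)c1cc(/C=C/C(=O)NCCC2CCN(Cc3ccc(F)cc3)CC2)cc(C(C)(C)C)c1O` gives 57500 nM, and compound 3 `CC(C)(C)c1cc(/C=C/C(=O)NCCC2CCN(Cc3ccc(F)cc3F)CC2)cc(C(C)(C)C)c1O` gives 62400 nM. Among these three, compound 1 holds the highest number, yet the change a 1.4-fold lower number from compound 1 to compound 2 (0.15 log units; within the scatter) and the change a 1.3-fold lower number from compound 1 to compound 3 (0.12 log units; within the scatter) both fall within the scatter, as does a 1.1-fold higher number from compound 2 to compound 3 (0.04 log units; within the scatter), so the three compounds cannot be told apart on this read-out.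

Compound 4 `CC(C)(C)c1cc(/C=C/C(=O)NCCC2CCN(Cc3ccccc3Cl)CC2)cc(C(C)(C)C)c1O` has not been measured. It differs from compound 1 in one place: chloro in place of hydrogen on an aromatic carbon. Among the compounds with values here, the steps that bear on this are those from compound 1 to compound 2 and from compound 1 to compound 3, where a fluoro in place of hydrogen, or phenyl replaced by 2,4-difluorophenyl, left the number where it stood within the scatter. Chloro in place of hydrogen on the same ring, read as phenyl to 2-chlorophenyl, is a change of the same sort, and nothing measured points to a different outcome. The expected step is therefore a 1.2-fold lower number from compound 1 to compound 4 (0.08 log units; within the scatter), nothing beyond the scatter. Compound 4 is estimated to give 68000 nM in this assay, with a range from 30000 nM to 150000 nM.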

Compound 4, half-maximal inhibitory concentration: 80200 nM
Compound 4: middle estimate off by 1.2-fold (0.07 log units), on the low side; the measured number falls inside the stated range.
By their numbers in this assay, from the lowest: compounds 2, 3, 4 and 1 (each within the scatter of the next).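

In this assay, within the data shown here, chloro in place of hydrogen on an aromatic carbon, ortho to a large group, gives a 1.0-fold lower number from compound 1 to compound 4 (0.01 log units; within the scatter), so on this benzyl ring a chlorine, like the fluorines before it, leaves no step that can be told from the scatter. The comparisons between the substituted rings agree: 2-chlorophenyl in place of 2,4-difluorophenyl gives a 1.3-fold higher number from compound 3 to compound 4 (0.11 log units; within the scatter), and 2-chlorophenyl in place of 4-fluorophenyl gives a 1.4-fold higher number from compound 2 to compound 4 (0.14 log units; within the scatter), which leaves all four compounds within the scatter of one another. No measurement shown offers a reason for this flat result.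

The compounds shown carry only hydrogen, fluoro and chloro on this ring, so it remains open whether a methoxy group, an amine or a carboxylic acid there would move the number beyond the scatter. Also open, going by these compounds, is whether any change away from this ring, such as a longer chain in place of the benzyl group, would separate compounds that these halogen changes cannot.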